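Compound 4: Swapping 4-bromophenyl for 2,4-dichlorophenyl

The source may report more compounds than this note shows. Statements on the series, on what has been measured and on what is new or still open speak of the compounds shown alone.

In a functional assay on THP-1 cells (Homo sapiens) for cytotoxicity, read by MTT assay, with a stated time of 24 h (on this read-out lower numbers stand for stronger inhibition and higher numbers for weaker inhibition), compound 1 `CN1C/C(=C\c2cccc([N+](=O)[O-])c2)C(=O)/C(=C/c2ccccc2F)C1` gives 1010 nM, compound 2 `CN1C/C(=C\c2ccc(F)cc2)C(=O)/C(=C/c2cccc([N+](=O)[O-])c2)C1` gives 7160 nM and compound 3 `CN1C/C(=C\c2ccc(Br)cc2)C(=O)/C(=C/c2cccc([N+](=O)[O-])c2)C1` gives 7690 nM. Compound 3 therefore stands level with compound 2, as the step of a 1.1-fold higher number from compound 2 to compound 3 (0.03 log units; within the scatter) shows, and clearly above compound 1.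

Compound 4 `CN1C/C(=C\c2cccc([N+](=O)[O-])c2)C(=O)/C(=C/c2ccc(Cl)cc2Cl)C1` differs from compound 3 at one place: 2,4-dichlorophenyl in place of 4-bromophenyl on a double-bonded chain carbon bound to a double-bonded ring carbon.

For the measured compounds named here, two measured steps bear on this change: a 7.1-fold higher number from compound 1 to compound 2 (0.85 log units; beyond the scatter) and a 7.6-fold higher number from compound 1 to compound 3 (0.88 log units; beyond the scatter). The incoming 2,4-dichlorophenyl group shares features with both the 2-fluorophenyl of compound 1 and the 4-bromophenyl of compound 3, so a drop smaller than those steps is expected. The expected change is a 3.1-fold lower number from compound 3 to compound 4 (0.49 log units; beyond the scatter). The estimated value for compound 4 is 2500 nM, within a range of 900 nM to 7000 nM.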

Compound 4, half-maximal inhibitory concentration: 3560 nM
Estimate against measurement, compound 4: 1.4-fold (0.15 log units) below; the measured number falls inside the stated range.
By their numbers in this assay, from the lowest: compound 1; then compounds 4, 2 and 3 (each within the scatter of the next, the first and the last beyond it).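

The 2,4-dichlorophenyl group separates from the 4-bromophenyl group (a 2.2-fold lower number from compound 3 to compound 4 (0.33 log units; beyond the scatter)) but not from the 4-fluorophenyl group (a 2.0-fold lower number from compound 2 to compound 4 (0.30 log units; within the scatter)), and it stays apart from the 2-fluorophenyl group of compound 1 (a 3.5-fold higher number from compound 1 to compound 4 (0.55 log units; beyond the scatter)). For the compounds shown here, the bromo for fluoro swap between compound 2 and compound 3 moved nothing beyond the scatter, so this is the first sign that a further change among halogen-bearing phenyl groups at this place can shift the number. No measurement here gives a reason for these differences.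

On these data alone, what remains open is how a phenyl group carrying an amine or a carboxylic acid would behave at this place. A plain phenyl group is also untested among the compounds shown.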